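The source may hold more compounds than are shown below. What is called first, only, known or untested is meant among the compounds shown, and "the series" means these compounds.

Measured in a functional assay on PC-3 cells (Homo sapiens) for cytotoxicity, read by MTT assay, with a stated time of 48 h; a higher number here means a weaker inhibitor, a lower number a stronger inhibitor:
compound 1 `Cc1nc(-c2c[nH]c3ccccc23)co1` gives 337000 nM
compound 2 `Oc1ccc(-c2nc(-c3c[nH]c4ccccc34)co2)cc1` gives 382000 nM
compound 3 `c1ccc2c(-c3coc(-c4ccncc4)n3)c[nH]c2c1` gives 298000 nM

The three numbers sit close together. Among the measured compounds shown here, the steps into compound 3, a 1.1-fold lower number from compound 1 to compound 3 (0.05 log units; within the scatter) and a 1.3-fold lower number from compound 2 to compound 3 (0.11 log units; within the scatter), are both within the scatter, as is a 1.1-fold higher number from compound 1 to compound 2 (0.05 log units; within the scatter), so no compound separates from the others in this assay.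

Compound 4 `c1ccc2c(-c3coc(C4CCNCC4)n3)c[nH]c2c1` differs from compound 3 by piperidin-4-yl in place of pyridin-4-yl on an aromatic carbon. The three measured steps all vary this same position on the shared core and none moved the number beyond the scatter; none, however, swaps an aromatic ring for a non-aromatic one, so they bear on the step only loosely. The expectation is a step of a 1.0-fold higher number from compound 3 to compound 4 (0.00 log units; within the scatter), within the scatter. Compound 4 is therefore estimated at 300000 nM in this assay, with a range of 120000 nM to 750000 nM.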

Compound 4, half-maximal inhibitory concentration: 407000 nM
Beside the measured number, compound 4's estimate is 1.4-fold (0.13 log units) below it; the range from low to high includes it.
By their numbers in this assay, from the lowest: compounds 3, 1, 2 and 4 (each within the scatter of the next).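

In this assay, the non-aromatic piperidin-4-yl in place of the aromatic pyridin-4-yl gives a 1.4-fold higher number from compound 3 to compound 4 (0.14 log units; within the scatter), so this position tolerates loss of ring aromaticity without the number leaving the scatter. The same holds against the other two groups, with a 1.1-fold higher number from compound 2 to compound 4 (0.03 log units; within the scatter) and a 1.2-fold higher number from compound 1 to compound 4 (0.08 log units; within the scatter), and all four compounds remain within the scatter of one another. No measurement on hand offers an explanation for this flat response.

Going by these compounds, whether a carboxylic acid or a longer alkyl chain at this position would move the number beyond the scatter remains open. So does the effect of an acyl group on the piperidine nitrogen.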